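Cyclopropyl for isopropyl on a nitrogen

This account rests on a few compounds, and the source may have more. Where it says the series, first, only, none or still open, it means among the compounds named here.

Compound 1 `CC(C)Nc1nc(Nc2ccccc2)c2ccccc2n1`: 12000 nM
Compound 2 `CC(C)Nc1nc(NC(C)C)c2ccccc2n1`: > 30000 nM
Compound 3 `CCNc1nc(NC(C)C)nc2ccccc12`: > 30000 nM

In an ADME assay on J774.A1 cells (Mus musculus) for inhibition, read by MTT assay, with a stated time of 72 h (on this read-out lower numbers stand for an effect already at smaller amounts and higher numbers for an effect only at larger amounts of compound), compound 2 stands at > 30000 nM, which is a limit and not a number. Compound 3 shares this limit, giving (the limit of > 30000 nM in this assay, at which 2 of the 3 values shown sit). Compound 4 `CC(C)Nc1nc(NC2CC2)nc2ccccc12` differs from compound 2 as follows: cyclopropyl in place of isopropyl on a nitrogen on an aromatic ring. The closest measured change is a step that the two limits leave unreadable from compound 2 to compound 3. The readable changes, an at least 2.5-fold higher number from compound 1 to compound 2 (0.39 log units; beyond the scatter) and an at least 2.5-fold higher number from compound 1 to compound 3 (0.39 log units; beyond the scatter), both remove phenyl, which compound 4 never carried. So no step beyond the scatter is expected in this assay, and another limit is likely. The expected change is a number no higher from compound 2 to compound 4 (the limit leaves the size open). Compound 4 is estimated at 30000 nM, within an expected range from 14000 nM to 60000 nM.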

Compound 4, half-maximal effective concentration: > 40000 nM
Compound 4 gave a limit, no number; the forecaster's own chance of this, stated with the estimate: 75%; middle value at least 1.3-fold (0.12 log units) away from the limit.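

Compound 2 and compound 4 both gave limits and not numbers, so the step between them cannot be read. The compounds shown leave open whether cyclopropyl in place of isopropyl on a nitrogen on an aromatic ring changes the effect at all.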